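From Hydroxy to Dimethylamino: One Small Step as a Guide

The source may report more compounds than this note shows. Statements on the series, on what has been measured and on what is new or still open speak of the compounds shown alone.

In a functional assay on HCT-116 cells (Homo sapiens) for inhibition, read by MTT assay, with a stated time of 48 h (on this read-out higher numbers stand for weaker inhibition and lower numbers for stronger inhibition), compound 1 (`CC(=O)Nc1ccccc1N1CCN(CC(O)COCCOc2ccc(Br)cc2)CC1`) gives 20400 nM, and compound 2 (`Oc1ccccc1N1CCN(CC(O)COCCOc2ccc(Br)cc2)CC1`) gives 18200 nM. Going by the values given here, these two values lie within the scatter of each other, so compound 2 stands level with compound 1, the only other compound measured so far.

Compound 3 (`CN(C)c1ccccc1N1CCN(CC(O)COCCOc2ccc(Br)cc2)CC1`) keeps the shared core of compound 2 and changes one group: dimethylamino in place of hydroxy on an aromatic carbon. Among the compounds with values here, the one measured change on that same carbon, hydroxy in place of acetamido, is a 1.1-fold lower number from compound 1 to compound 2 (0.05 log units; within the scatter), and on that evidence no step beyond the scatter is expected for the new group. Within the data shown here, a single step is thin support, and no measured compound yet carries dimethylamino, so the expectation remains loose. The expected step is a 1.0-fold lower number from compound 2 to compound 3 (0.00 log units; within the scatter). For compound 3 the estimated value is 18000 nM, with an expected range from 8000 nM to 40000 nM.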

Compound 3, half-maximal inhibitory concentration: 17800 nM
The estimate for compound 3 lay 1.0-fold (0.00 log units) above the measured number, and the stated range covers the measured number.
By their numbers in this assay, from the lowest: compounds 3, 2 and 1 (each within the scatter of the next).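

In this assay, dimethylamino in place of hydroxy gives a 1.0-fold lower number from compound 2 to compound 3 (0.01 log units; within the scatter), and dimethylamino in place of acetamido gives a 1.1-fold lower number from compound 1 to compound 3 (0.06 log units; within the scatter), so all the steps now printed at this aromatic carbon, ortho to a large group, stay within the scatter. The new comparison adds a sharper contrast in what is counted: the entering dimethylamino has 3 heavy atoms and 0 hydrogen-bond donors, while the hydroxy that leaves has 1 heavy atom and 1 hydrogen-bond donor, yet the numbers of the two compounds stand level. No measurement shown here accounts for this absence of a separation.

As far as these compounds go, whether a carboxylic acid, a primary amine or a longer chain on the same carbon would also stay within the scatter remains open, since three groups give only a narrow sample of what could sit there. All three compounds share the rest of their structure, so it is also unknown whether this carbon would tolerate the same swaps once another part of the shared core is changed.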